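The source may hold more compounds than are shown below. What is called first, only, known or untested is meant among the compounds shown, and "the series" means these compounds.

The measured compounds in a functional assay on QGY7701 cells (Homo sapiens) for cytotoxicity, read by MTT assay, with a stated time of 24 h; on this read-out higher numbers stand for weaker inhibition and lower numbers for stronger inhibition:

Compound 1 `C=CC1=C(C(=O)NCCCCC)C(c2ccc(Cl)c(Cl)c2)OC1` gives > 100000 nM, which is a limit of the assay and not a number.
Compound 2 `C=CC1=C(C(=O)NCc2ccc(C)cc2)C(c2ccc(OC)c(OC)c2)OC1` gives 69100 nM.
Compound 3 `C=CC1=C(C(=O)NCCC)C(c2ccc(OC)cc2)OC1` gives > 100000 nM, again a limit of the assay rather than a number.

Compound 1 therefore stands at the edge of what this assay can report: its value is the assay limit, and it shares that position with compound 3, as described by the limit of > 100000 nM in this assay, at which 2 of the 3 values shown sit. Only compound 2 returns an actual number, and that number is itself high on the half-maximal inhibitory concentration scale. Taken together, the three values show a series with little measurable cytotoxicity under these conditions.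

The step from compound 1 to compound 4 `C=CC1=C(C(=O)O)C(c2ccc(Cl)c(Cl)c2)OC1` is a single change at the carbonyl carbon of the shared core: hydroxy in place of pentylamino on a carbonyl carbon. The pentylamino chain is gone and a hydroxy group takes its place, so compound 4 is the free acid of the amide that compound 1 represents. Among the compounds with values here, no measured pair in the set shows this kind of exchange, so there is no step to lean on. Because compound 1 already sits at the limit, as the limit of > 100000 nM in this assay, at which 2 of the 3 values shown sit, records, the starting point gives no room to read a gain or loss with confidence, and the expected step from compound 1 to compound 4 is a number no higher from compound 1 to compound 4 (the limit leaves the size open), essentially none beyond the scatter. Compound 4 is accordingly estimated at 100000 nM, within a range of 30000 nM to 300000 nM, with a strong chance that this assay again returns only a limit.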

Compound 4, half-maximal inhibitory concentration: > 100000 nM
Compound 4: only a limit was reported (the forecaster's own chance of this, stated with the estimate: 75%); the middle value sits exactly at the limit.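

In this assay compound 4 gives > 100000 nM, which is a limit of the assay and not a number. Compound 1 also stands at a limit, so no step can be read between compound 1 and compound 4: the limit of > 100000 nM in this assay, at which 3 of the 4 values shown sit. The compounds shown leave open whether hydroxy in place of pentylamino on a carbonyl carbon changes cytotoxicity at all.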